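The source may hold more compounds than are shown below. What is called first, only, known or untested is meant among the compounds shown, and "the series" means these compounds.

Working notes on the series. Among the measured compounds shown here, compound 1 `CCCOC(=O)C1=C(C)NC(=O)NC1c1ccco1` and compound 2 `COC(=O)C1=C(C)NC(=O)NC1c1ccoc1` share a core and differ in more than one place, so no single step between them is counted. In an assay on membranes from HeLa cells for displacement of a labelled ligand from adenosine receptor A3 (Homo sapiens), read by scintillation counting, with a stated time of 180 min, tested at 1 uM (on this read-out higher numbers stand for more inhibition at the one concentration tested (going by the name of the read-out) and lower numbers for less inhibition), compound 1 gives 3%. In this assay compound 2 gives 2%, a number within the usual scatter of the value of compound 1; both readings lie close to zero. Compound 3 `CCCOC(=O)C1=C(C)NC(=O)NC1c1ccoc1` is not yet measured. Compound 3 differs from compound 2 by ethyl in place of hydrogen on a saturated chain carbon bound to an oxygen next to a carbonyl group. A propoxycarbonyl group is already present in compound 1, whose value of 3% sits at the same near-zero level as compound 2, so the step from compound 2 to compound 3 is expected to stay within the scatter in this assay, with no direction to it. The expected step of a number 1 percentage points higher from compound 2 to compound 3 (within the scatter) is accordingly flat. Compound 3 is estimated at 3% in this assay, with an expected range from -5% to 12%.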

Compound 3, a percentage reported as inhibition, at one concentration (the size of the read-out at that concentration, not a potency): 11%
Compound 3: middle estimate off by 8 percentage points, on the low side, within the range that was stated.
By their numbers in this assay, from the lowest: compounds 2, 1 and 3 (each within the scatter of the next).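

In this assay, among the compounds shown here, ethyl in place of hydrogen on a saturated chain carbon bound to an oxygen next to a carbonyl group gives a number 9 percentage points higher from compound 2 to compound 3 (within the scatter), the first step that can be read at this position. With the propoxycarbonyl group held, furan-3-yl in place of furan-2-yl on a saturated ring carbon gives a number 8 percentage points higher from compound 1 to compound 3 (within the scatter), so neither change carries a reading beyond the scatter. No measurement on hand bears on either step.

On these data alone, a longer chain such as butyl, or a carboxylic acid in place of the propoxycarbonyl group, remains open as a way to reach a reading clear of the scatter. Also open, as far as these compounds go, is whether the step from methoxycarbonyl to propoxycarbonyl reads the same with furan-2-yl on the saturated ring carbon.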